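Swapping methoxy for amino on a thienopyridine ester

The source may hold more compounds than are shown below. What is called first, only, known or untested is meant among the compounds shown, and "the series" means these compounds.

Compound 1, `COC(=O)c1sc2cc(-c3cccs3)cnc2c1N`: 26900 nM
Compound 2, `COC(=O)c1sc2cc(-c3ccc(OC)cc3)cnc2c1N`: > 150000 nM

In a functional assay on MCF7 cells (Homo sapiens) for inhibition, read by sulforhodamine B assay, with a stated time of 48 h (a lower number here means a stronger inhibitor of growth, a higher number a weaker inhibitor of growth), compound 1 gives 26900 nM. For compound 2 only a limit is known, > 150000 nM, which is the limit of this assay itself (the limit of > 150000 nM in this assay, at which 1 of the 2 values shown sits). Compound 2 therefore stands at the weak end of what this assay can report. Compound 3, `COC(=O)c1sc2cc(-c3ccc(N)cc3)cnc2c1N`, differs from compound 2 by one change: amino in place of methoxy on an aromatic carbon. With no measured pair to lean on, the size and direction of the step from compound 2 to compound 3 in this assay cannot be judged from the shown numbers. The step is nonetheless estimated as an at least 1.5-fold lower number from compound 2 to compound 3 (0.17 log units; that floor lies within the scatter). Compound 3 is expected to give about 100000 nM, with a likely range from 20000 nM to 300000 nM.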

Compound 3, concentration for 50% growth inhibition: 108000 nM
Compound 3: the middle estimate sits 1.1-fold (0.03 log units) below what was measured, and the stated range covers the measured number.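

With amino on this ring, the 4-substituted aryl series now has a real number in this assay, but the change from methoxy can be read only as a floor: an at least 1.3-fold lower number from compound 2 to compound 3 (0.14 log units; that floor lies within the scatter). The value for compound 2 is a limit: the limit of > 150000 nM in this assay, at which 1 of the 3 values shown sits. Thiophen-2-yl still gives the lower number, with 4-aminophenyl in its place producing a 4.0-fold higher number from compound 1 to compound 3 (0.60 log units; beyond the scatter), so the group at this place on the shared core does affect growth inhibition.

On these data alone, the true size of the methoxy-to-amino step stays open. So does whether a carboxylic acid or a dimethylamino group at the same place would lower the number further.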